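A few compounds are considered here, and "the series" means these few. Any claim that something is new, unique, unknown or untested is made for them only; others in the source may bear on it.

Going by the values given here, compound 2, `N#CC1=C(N)Oc2c(N)cc3nc4ccccc4nc3c2C12C(=O)N(Cc1cnnn1-c1cc(Cl)ccc1Cl)c1ccccc12`, is the only compound with a definite number in a functional assay on HepG2 cells (Homo sapiens) for antiproliferative activity, read by MTT assay, with a stated time of 48 h; a higher number here means a weaker inhibitor, a lower number a stronger inhibitor; in this assay compound 2 gives 33100 nM. Compound 1, `N#CC1=C(N)Oc2c(N)cc3nc4ccccc4nc3c2C12C(=O)N(Cc1cnnn1-c1ccc(F)cc1)c1ccccc12`, gives > 50000 nM in this assay, and that value is a limit of the assay rather than a number (the limit of > 50000 nM in this assay, at which 1 of the 2 values shown sits). Among the compounds with values here, the single measured step is an at least 1.5-fold lower number from compound 1 to compound 2 (0.17 log units; that floor lies within the scatter). Compound 3, `COc1cc(-n2nncc2CN2C(=O)C3(C(C#N)=C(N)Oc4c(N)cc5nc6ccccc6nc5c43)c3ccccc32)c(OC)cc1Cl`, differs from compound 2 in one place: 4-chloro-2,5-dimethoxyphenyl in place of 2,5-dichlorophenyl on an aromatic nitrogen. That measured step also swapped the aryl group on the same aromatic nitrogen and stayed within the scatter, so only a small step, in no sure direction, is expected: a 1.1-fold lower number from compound 2 to compound 3 (0.04 log units; within the scatter). Compound 3 is therefore estimated at 30000 nM, within 10000 nM to 90000 nM.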

Compound 3, half-maximal inhibitory concentration: > 50000 nM
Compound 3: a limit, no number (the forecaster's own chance of this, stated with the estimate: 35%); middle value at least 1.6-fold (0.22 log units) away from the limit.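

On the aromatic nitrogen, 4-chloro-2,5-dimethoxyphenyl in place of 2,5-dichlorophenyl gives an at least 1.5-fold higher number from compound 2 to compound 3 (0.17 log units; that floor lies within the scatter) in this assay, so the definite reading of compound 2 does not survive this swap. The value of compound 3 is a limit, not a number, and it is the same limit that compound 1 reached: the limit of > 50000 nM in this assay, at which 2 of the 3 values shown sit. The step from compound 1 to compound 3 cannot be read, as both values are limits.

Still open, on these data alone, is whether a phenyl ring carrying an amine or a carboxylic acid would give a definite, lower number. A longer alkyl chain on that nitrogen in place of the aryl ring is equally untested here.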